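The source may report more compounds than this note shows. Statements on the series, on what has been measured and on what is new or still open speak of the compounds shown alone.

Three compounds have been measured in an ADME assay on L02 cells (Homo sapiens) for cytotoxicity, read by MTT assay, with a stated time of 24 h; a lower number here means a stronger inhibitor, a higher number a weaker inhibitor:

Compound 1, `O=C1/C(=C/c2cccnc2)CN(S(=O)(=O)c2ccccc2)C/C1=C\c1ccccc1F`, gives 15300 nM.
Compound 2, `O=C1/C(=C/c2cccnc2)CN(S(=O)(=O)c2ccccc2)C/C1=C\c1ccccc1C(F)(F)F`, gives 12500 nM.
Compound 3, `O=C1/C(=C/c2ccncc2)CN(S(=O)(=O)c2ccc(C(F)(F)F)cc2)C/C1=C\c1ccccc1C(F)(F)F`, gives 13800 nM.

Compound 2 and compound 1 share a core and differ in one place: fluoro in place of trifluoromethyl on an aromatic carbon. This change produced a 1.2-fold higher number from compound 2 to compound 1 (0.09 log units; within the scatter), so the two numbers cannot be told apart here. Compound 3 differs from compound 2 in more than one place, and the difference between the two cores is not broken down here; their two numbers lie within the usual scatter of each other.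

Compound 4, `O=C1/C(=C/c2ccncc2)CN(S(=O)(=O)c2ccc(F)cc2)C/C1=C\c1ccccc1C(F)(F)F`, has not yet been measured. It stands to compound 3 as compound 1 stands to compound 2: fluoro in place of trifluoromethyl on an aromatic carbon. This is the same kind of change, not the same one, since the earlier fluoro sits ortho to a large group and this one para to a large group. Because the earlier step was a 1.2-fold higher number from compound 2 to compound 1 (0.09 log units; within the scatter), the step from compound 3 to compound 4 is expected to be small as well, about a 1.0-fold higher number from compound 3 to compound 4 (0.01 log units; within the scatter). Compound 4 is therefore estimated at 14000 nM in this assay, between 7000 nM and 28000 nM.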

Compound 4, half-maximal inhibitory concentration: 12900 nM
Estimate against measurement, compound 4: 1.1-fold (0.04 log units) above, within the range that was stated.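

In this assay, fluoro in place of trifluoromethyl gives a 1.1-fold lower number from compound 3 to compound 4 (0.03 log units; within the scatter), so the two numbers cannot be told apart. Set beside the earlier case, the change looks the same on both cores, as the two steps cannot be separated: the same change on two cores in this assay, a 1.2-fold higher number (0.09 log units; within the scatter) from compound 2 to compound 1 and a 1.1-fold lower number (0.03 log units; within the scatter) from compound 3 to compound 4, 1.3-fold (0.12 log units) apart, within the scatter of two such steps. This shows that, on these two cores, the change left the number within the usual scatter, but it does not show that the step would stay this small on a further core, and two steps this small reveal no measurable effect of the change that could be carried from one core to another.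

The compounds shown leave open whether a different group in the place of the trifluoromethyl, such as an amine, a carboxylic acid or a longer chain, would move the number beyond the scatter. From the compounds shown here alone, it also remains open what would happen with plain hydrogen at that carbon, with neither fluoro nor trifluoromethyl present.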